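A few compounds are considered here, and "the series" means these few. Any claim that something is new, unique, unknown or untested is made for them only; others in the source may bear on it.

The work concerns inhibition in a functional assay on A549 cells (Homo sapiens) for inhibition, read by MTT assay, with a stated time of 72 h; on this read-out lower numbers stand for stronger inhibition and higher numbers for weaker inhibition. Among the compounds with values here, compound 1, `COc1ccccc1/C=C/C=N/N1C(=S)NC2C1N(C)C(=O)N2c1ccccc1`, is the first member. In this assay compound 1 gives only a limit, > 100000 nM. Compound 2, `CCN1C(=O)N(c2ccccc2)C2NC(=S)N(/N=C/C=C/c3ccccc3OC)C21`, differs from compound 1 by a single change, (methyl in place of hydrogen on a saturated chain carbon bound to an amide-type nitrogen in a ring). In this assay compound 2 likewise gives a limit, > 100000 nM. The step that the two limits leave unreadable from compound 1 to compound 2 therefore cannot be read. Compound 3, `CCN1C(=O)N(CC)C2C1N=C(SC)N2/N=C/C=C/c1ccccc1[N+](=O)[O-]`, carries a different core; the difference between the two cores is not broken down here. In this assay compound 3 also gives a limit, > 100000 nM. Within the data shown here, all values so far sit at the limit of > 100000 nM in this assay, at which 3 of the 3 values shown sit, so no measured step reveals any size of effect.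

Compound 4, `CCSC1=NC2C(N(CC)C(=O)N2CC)N1/N=C/C=C/c1ccccc1[N+](=O)[O-]`, has not yet been measured. It differs from compound 3 by methyl in place of hydrogen on a saturated chain carbon bound to a sulfur. Among the measured compounds shown here, this is the same kind of change as the one from compound 1 to compound 2, but the place differs: in the earlier pair the methyl enters on a saturated chain carbon bound to an amide-type nitrogen in a ring, whereas here it enters on a saturated chain carbon bound to a sulfur. The step from compound 3 to compound 4 is expected to be a step that the limit leaves unreadable from compound 3 to compound 4, resting on compound 3 sitting at the limit of > 100000 nM in this assay, at which 3 of the 3 values shown sit, and on the comparable change from compound 1 to compound 2 giving no readable shift. Compound 4 is thus expected to give about 150000 nM, within 40000 nM to 500000 nM, and most probably only a limit again.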

Compound 4, half-maximal inhibitory concentration: > 100000 nM
Compound 4 gave a limit, no number; the forecaster's own chance of this, stated with the estimate: 80%; the middle value lies beyond the limit too.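

In this assay compound 4, like compound 3, gives only a limit, so no size can be read for the step between these two compounds: the limit of > 100000 nM in this assay, at which 4 of the 4 values shown sit.

The compounds shown leave open whether any of them inhibits measurably in this assay, and what methyl in place of hydrogen on a saturated chain carbon bound to a sulfur would do where a number can be read.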